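Sulfur-linked side chain and cell toxicity: working notes

This account rests on a few compounds, and the source may have more. Where it says the series, first, only, none or still open, it means among the compounds named here.

Compound 1 `Cc1cc(N2CC[C@@H](C)[C@@H](N(C)c3ncnc4[nH]ccc34)C2)n2nc(SCc3nc4ccccc4[nH]3)nc2n1` gives 40200 nM in a toxicity assay on GES1 cells (Homo sapiens) for inhibition, read by MTT assay, with a stated time of 72 h; a lower number here means a stronger inhibitor, a higher number a weaker inhibitor.
Compound 2 `Cc1cc(N2CC[C@@H](C)[C@@H](N(C)c3ncnc4[nH]ccc34)C2)n2nc(SCc3ccc(F)c(Cl)c3)nc2n1` is reported only as the assay limit, > 100000 nM.
Compound 3 `Cc1cc(N2CC[C@@H](C)[C@@H](N(C)c3ncnc4[nH]ccc34)C2)n2nc(SCCCc3ccccc3)nc2n1` is likewise reported only as the assay limit, > 100000 nM.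
Compound 4 `C#CSc1nc2nc(C)cc(N3CC[C@@H](C)[C@@H](N(C)c4ncnc5[nH]ccc45)C3)n2n1` is not yet measured.

Compound 3 thus stands at the ceiling of this assay rather than at a number, and it shares that ceiling with compound 2, as noted in the limit of > 100000 nM in this assay, at which 2 of the 3 values shown sit. For the measured compounds named here, compound 1 is the only member with a measured value. The steps away from it, an at least 2.4-fold higher number from compound 1 to compound 2 (0.39 log units; beyond the scatter) and an at least 2.4-fold higher number from compound 1 to compound 3 (0.39 log units; beyond the scatter), both run upward into the limit. The comparison a step that the two limits leave unreadable from compound 2 to compound 3 between two limits cannot be read.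

The move to compound 4 is ethynyl in place of 3-phenylpropyl on a sulfur. Every change of the sulfur-bound group seen so far took the number from a readable value up to the limit; no change has yet brought a compound back below it. The new group is much smaller and carries no ring, but nothing measured here speaks to that. The expectation for compound 4 is that it remains at or near the ceiling, so the step that the limit leaves unreadable from compound 3 to compound 4 is expected to be unreadable or small. Compound 4 is estimated at 110000 nM, within 35000 nM to 300000 nM, most probably reported again as a limit.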

Compound 4, half-maximal inhibitory concentration: > 100000 nM
Compound 4 was reported as a limit; the forecaster's own chance of this, stated with the estimate: 70%; the middle value is on the limit's open side.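

In this assay, ethynyl in place of the (1H-benzimidazol-2-yl)methyl group of compound 1 gives an at least 2.4-fold higher number from compound 1 to compound 4 (0.39 log units; beyond the scatter), the same upward run into the limit already seen with 3-chloro-4-fluorobenzyl and 3-phenylpropyl. Ethynyl carries no ring, so among the groups shown on this sulfur a benzene ring is not needed for a compound to sit at the ceiling, and compound 1, with its (1H-benzimidazol-2-yl)methyl group, remains the only member with a readable value. The series now stands as follows: the limit of > 100000 nM in this assay, at which 3 of the 4 values shown sit.

Going by these compounds, the steps from compound 2 and from compound 3 to compound 4 cannot be read, so how far these three compounds lie apart remains unknown. On these data alone, it also remains open whether a sulfur-bound chain ending in an amine or a carboxylic acid would give a readable value, as compound 1 does, or would stay at the limit.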